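A carboxylic acid replaces the acetamide on the benzylamine

The source may report more compounds than this note shows. Statements on the series, on what has been measured and on what is new or still open speak of the compounds shown alone.

Compound 3 (`COc1ccc(/C=C\c2cc(OC)c(OC)c(OC)c2)cc1OCc1ccc(CNCCNC(C)=O)cc1`) carries the shared core with a ((2-acetamidoethyl)amino)methyl arm. In an ADME assay on HEK293 cells (Homo sapiens) for cytotoxicity, read by CCK-8 assay, with a stated time of 48 h (on this read-out lower numbers stand for stronger inhibition and higher numbers for weaker inhibition), compound 3 reaches only the limit of the measurement, > 50000 nM. Two of the three measured values sit at that limit (the limit of > 50000 nM in this assay, at which 2 of the 3 values shown sit). Compound 1 (`COc1ccc(/C=C\c2cc(OC)c(OC)c(OC)c2)cc1OCc1ccc(CN2C[C@H](O)C[C@@H]2C(=O)O)cc1`), with 2-carboxy-4-hydroxypyrrolidin-1-yl on the saturated chain carbon bound to an aromatic carbon, also gives only a limit, > 50000 nM. Among the measured compounds shown here, compound 2 (`COc1ccc(/C=C\c2cc(OC)c(OC)c(OC)c2)cc1OCc1ccc(CN2CC[C@@H](C(=O)O)C2)cc1`), with 3-carboxypyrrolidin-1-yl in that place, is the one compound with a number, 27000 nM. The step of an at least 1.8-fold higher number from compound 2 to compound 3 (0.26 log units; that floor lies within the scatter) is the only movement with a direction, a step that the two limits leave unreadable from compound 1 to compound 3 cannot be read, and an at least 1.8-fold lower number from compound 1 to compound 2 (0.26 log units; that floor lies within the scatter) stays within the scatter.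

Compound 4 (`COc1ccc(/C=C\c2cc(OC)c(OC)c(OC)c2)cc1OCc1ccc(CNC(C)(C)C(=O)O)cc1`) differs from compound 3 by 1-carboxy-1-methylethyl in place of 2-acetamidoethyl on an amine nitrogen. For the measured compounds named here, no measured pair makes this exact exchange; the nearest is the one from compound 2 to compound 3, where a 3-carboxypyrrolidin-1-yl gives way to the acetamide and the number moves only at the floor of an at least 1.8-fold higher number from compound 2 to compound 3 (0.26 log units; that floor lies within the scatter). Compound 4 is therefore expected to stay close to where compound 3 stands, with a step of an at least 1.1-fold lower number from compound 3 to compound 4 (0.04 log units; that floor lies within the scatter). The estimate for compound 4 in this assay is 45000 nM, between 20000 nM and 100000 nM.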

Compound 4, half-maximal inhibitory concentration: > 50000 nM
Compound 4: no number, only a limit; the forecaster's own chance of this, stated with the estimate: 55%; middle value at least 1.1-fold (0.04 log units) from the limit.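

In this assay compound 4 gives only a limit, > 50000 nM. This shows that an open-chain arm carrying a carboxylic acid, (1-carboxy-1-methylethyl)amino on the saturated chain carbon, also gives no number on this read-out, just as the 2-acetamidoethyl arm of compound 3 and the 2-carboxy-4-hydroxypyrrolidin-1-yl arm of compound 1 give none, while compound 2, with its 3-carboxypyrrolidin-1-yl arm, goes against any rule that a carboxylic acid here settles the outcome either way: the limit of > 50000 nM in this assay, at which 3 of the 4 values shown sit. Among the compounds shown here, the one step that can be read is an at least 1.8-fold higher number from compound 2 to compound 4 (0.26 log units; that floor lies within the scatter), and the steps that join compound 4 to compound 3 and to compound 1 run between two limits and cannot be read.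

With so many values at the limit, the compounds shown leave open how these arms truly rank, and whether compound 2 really parts from the others by more than the scatter. They also leave open what a longer chain between the amine nitrogen and the carboxylic acid, or a piperidine ring bearing that acid, would give in this assay.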